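The source may report more compounds than this note shows. Statements on the series, on what has been measured and on what is new or still open speak of the compounds shown alone.

Measured compounds:
compound 1 `Cc1c(C(=O)Nc2ccc(Oc3ncnc4[nH]cc(-c5ccccc5)c34)c(F)c2)c(=O)c2cc(F)ccc2n1C`: > 10000 nM
compound 2 `CCc1ccc2c(c1)c(=O)c(C(=O)Nc1ccc(Oc3cccc4occ(-c5ccccc5)c34)c(F)c1)c(C)n2C`: 192 nM
compound 3 `CCc1ccc2c(c1)c(=O)c(C(=O)Nc1ccc(Oc3ccnc(C(N)=O)c3)c(F)c1)c(C)n2C`: 4380 nM

All three were tested in an assay on isolated protein for inhibition of tyrosine-protein kinase receptor UFO (Homo sapiens), read by FRET and Z'-LYTE, with a stated time of 1.5 h; on this read-out higher numbers stand for weaker inhibition and lower numbers for stronger inhibition. For compound 1 the result in this assay is a limit rather than a number: compound 1 gives > 10000 nM. This is the limit noted in the limit of > 10000 nM in this assay, at which 1 of the 3 values shown sits. Compound 2 carries an ethyl group on the shared core and a different ether-linked group; in this assay compound 2 gives 192 nM. Compound 3 also carries the ethyl group, with yet another ether-linked group, and in this assay compound 3 gives 4380 nM. Compound 2 and compound 3 each differ from compound 1 in more than one place, so no single step can be read between them and compound 1.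

Compound 4 `C=C(C)c1ccc2c(c1)c(=O)c(C(=O)Nc1ccc(Oc3ncnc4[nH]cc(-c5ccccc5)c34)c(F)c1)c(C)n2C` has not yet been measured. It keeps the ether-linked group of compound 1 and changes only the core: 1-methylethenyl in place of fluoro on an aromatic carbon. For the measured compounds named here, no measured pair shows this change by itself. Compound 2, whose core carries a carbon substituent rather than fluoro, gives 192 nM, which hints that a carbon substituent at this place is tolerated. Compound 4 is expected to gain in this assay, with a step of an at least 3.3-fold lower number from compound 1 to compound 4 (0.52 log units; beyond the scatter) beyond the scatter. Compound 4 is estimated at 3000 nM, within 500 nM to 20000 nM.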

Compound 4, half-maximal inhibitory concentration: 170 nM
Compound 4: the middle estimate sits 18-fold (1.25 log units) above what was measured; the measured number lies below the stated range.
By their numbers in this assay, from the lowest: compounds 4 and 2 (each within the scatter of the next); then compound 3. At a limit, above all of these: compound 1.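

In this assay, replacing fluoro with 1-methylethenyl on an aromatic carbon of the shared core gives an at least 58-fold lower number from compound 1 to compound 4 (1.76 log units; beyond the scatter) while the ether-linked group stays unchanged. For the compounds shown here, this is the first pair here that differs in one place only, so the gain can be tied to this single change, on a six-membered aromatic ring of carbon only, and not to a difference in the ether-linked group. Compound 1 gives > 10000 nM, which is a limit of the assay and not a number: the limit of > 10000 nM in this assay, at which 1 of the 4 values shown sits.

The compounds shown leave open whether the gain needs the double bond of 1-methylethenyl, which an isopropyl group at this place would test, and whether a small methyl group, an amine or a carboxylic acid there would give a similar result. They also leave open whether the same change would bring a similar gain on compounds that carry a different ether-linked group.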